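The compounds below may be only part of what the source reports. "The series", "measured", "known", "first", "only" and "open" are said of these compounds alone.

Measured so far:
compound 1, `COc1cc(OC)c(C(=O)/C=C/c2cn(-c3ccccc3)nc2-c2cccnc2)c(OC)c1`: 1400 nM
compound 2, `COc1ccc(OC)c(C(=O)/C=C/c2cn(-c3ccccc3)nc2-c2cccnc2)c1`: 3400 nM

Both compounds were tested in a functional assay on HepG2 cells (Homo sapiens) for inhibition, read by sulforhodamine B assay, with a stated time of 72 h; a lower number here means a stronger inhibitor, a higher number a weaker inhibitor. Compound 1 gives the lower of the two numbers, 1400 nM, while compound 2 gives 3400 nM, a gap beyond the usual scatter, so compound 1 is the stronger inhibitor of the pair. The two share the same core and differ only in how the methoxy groups are arranged on the ring that carries the carbonyl.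

Compound 3, `COc1cc(OC)c(C(=O)/C=C/c2cn(-c3ccccc3)nc2-c2ccncc2)c(OC)c1`, keeps the methoxy arrangement of compound 1 and alters the pyridine on the five-membered ring instead: pyridin-4-yl in place of pyridin-3-yl on an aromatic carbon. For the measured compounds named here, no measured pair shows this exchange, so its effect cannot be read from the data. Shifting the nitrogen within an otherwise unchanged pyridine is a modest alteration, and the expectation is a small step, if any, likely toward a somewhat higher number; the step from compound 1 to compound 3 is expected to be a 1.6-fold higher number from compound 1 to compound 3 (0.20 log units; within the scatter). Compound 3 is therefore expected to give about 2200 nM in this assay, with a plausible range from 800 nM to 6500 nM.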

Compound 3, half-maximal inhibitory concentration: 1700 nM
Compound 3: the middle estimate sits 1.3-fold (0.11 log units) above what was measured; the measured number falls inside the stated range.
By their numbers in this assay, from the lowest: compounds 1, 3 and 2 (each within the scatter of the next, the first and the last beyond it).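

Exchanging pyridin-3-yl for pyridin-4-yl on this aromatic carbon of the five-membered ring gives, in this assay, a 1.2-fold higher number from compound 1 to compound 3 (0.08 log units; within the scatter), so this assay does not separate the two compounds. For the compounds shown here, this is the first reading at this position, since the earlier pair differed only in how the methoxy groups are arranged on the ring that carries the carbonyl, and it shows that, with the methoxy arrangement of compound 1, the place of the nitrogen in this pyridine makes no difference that can be told from the scatter. The data offer nothing that would explain this result.

Going by these compounds, this is a single pair, so it remains open whether the same exchange would be as quiet with the methoxy arrangement of compound 2. Also open, on these data alone, is what this position would accept beyond these two pyridines: a pyridin-2-yl group, a ring carrying a carboxylic acid or an amine, or a saturated ring such as morpholine could each give a quite different number.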